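Cytotoxicity notes: carbonyl substituent change on compound 1

A few compounds are considered here, and "the series" means these few. Any claim that something is new, unique, unknown or untested is made for them only; others in the source may bear on it.

- compound 1 `O=C1c2ccccc2C(=O)N1CCOC(=S)N(C(=O)c1ccc([N+](=O)[O-])cc1)c1ccc(Cl)cc1`: > 100000 nM
- compound 2 `Cc1ccc(N(C(=O)c2ccccc2C)C(=S)OCCN2C(=O)c3ccccc3C2=O)cc1`: > 100000 nM
- compound 3 `Cc1ccc(N(C(=O)c2ccccc2[N+](=O)[O-])C(=S)OCCN2C(=O)c3ccccc3C2=O)cc1`: 100000 nM

In an ADME assay on MT4 cells (Homo sapiens) for cytotoxicity, read by MTT assay (on this read-out higher numbers stand for lower toxicity in this test and lower numbers for higher toxicity in this test), compound 1 gives > 100000 nM, which is a limit and not a number. Among the compounds with values here, the series so far shows (the limit of > 100000 nM in this assay, at which 2 of the 3 values shown sit). Compound 4 `O=C1c2ccccc2C(=O)N1CCOC(=S)N(C(=O)c1cccc(Cl)c1Cl)c1ccc(Cl)cc1` differs from compound 1 by 2,3-dichlorophenyl in place of 4-nitrophenyl on a carbonyl carbon. Within the data shown here, the only measured step is a number no higher from compound 2 to compound 3 (the limit leaves the size open), and it concerns a different change. Among the measured compounds shown here, compound 3, with 100000 nM, holds the only number, so no step beyond the scatter is expected in this assay. The expected size is a number no higher from compound 1 to compound 4 (the limit leaves the size open), with no direction expected. For compound 4 the estimate is 100000 nM, with an expected range from 40000 nM to 200000 nM.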

Compound 4, half-maximal cytotoxic concentration: 54000 nM
Beside the measured number, compound 4's estimate is 1.9-fold (0.27 log units) above it, within the range that was stated.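

On the core of compound 1, the carbonyl carbon bound to the amide-type nitrogen now gives a readable number once 2,3-dichlorophenyl replaces 4-nitrophenyl. In this assay, the change gives an at least 1.8-fold lower number from compound 1 to compound 4 (0.26 log units; that floor lies within the scatter). Only this floor can be read, so the change is not shown to go beyond the scatter, and its full size stays open because the starting point is a limit: the limit of > 100000 nM in this assay, at which 2 of the 4 values shown sit.

Still open, as far as these compounds go, is whether an amine or a carboxylic acid on this aromatic ring would shift the reading. A longer alkyl chain in place of the ring at this carbonyl carbon is equally untested here.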